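Changing the aryl group on the shared core

The compounds below may be only part of what the source reports. "The series", "measured", "known", "first", "only" and "open" are said of these compounds alone.

Compound 1 `Cn1c(=O)c(=O)n(C2CCCC2)c2nc(N/N=C/c3ccc(C(F)(F)F)cc3)ncc21` gives 40600 nM in a functional assay on A549 cells (Homo sapiens) for antiproliferative activity, read by MTT assay; a higher number here means a weaker inhibitor, a lower number a stronger inhibitor.
Compound 2 `Cn1c(=O)c(=O)n(C2CCCC2)c2nc(N/N=C/c3ccco3)ncc21` gives only an assay limit, > 100000 nM, in this assay.
Compound 3 `COc1ccc(/C=N/Nc2ncc3c(n2)n(C2CCCC2)c(=O)c(=O)n3C)c(OC)c1` gives only an assay limit, > 100000 nM, in this assay.

Among the three measured compounds, compound 1 is the only one with an actual number in this assay; the other two values are limits. Compound 4 `Cn1c(=O)c(=O)n(C2CCCC2)c2nc(N/N=C/c3cccc([N+](=O)[O-])c3)ncc21` is not yet measured. It differs from compound 1 in one place: 3-nitrophenyl in place of 4-(trifluoromethyl)phenyl on a carbon with a double bond to nitrogen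

Within the data shown here, two measured steps bear on this change. Both also replace the 4-(trifluoromethyl)phenyl of compound 1 with another group on the carbon with a double bond to nitrogen. Those steps were an at least 2.4-fold higher number from compound 1 to compound 2 (0.39 log units; beyond the scatter) and an at least 2.4-fold higher number from compound 1 to compound 3 (0.39 log units; beyond the scatter). Their exact sizes cannot be read, because of the limit of > 100000 nM in this assay, at which 2 of the 3 values shown sit. The step that the two limits leave unreadable from compound 2 to compound 3 adds nothing readable.

Among the measured compounds shown here, both known replacements weakened the compound beyond the scatter, so a similar weakening is expected for compound 4, though a nitro-bearing phenyl is a new case and no measured step fixes its size. The estimated step is a 1.7-fold higher number from compound 1 to compound 4 (0.24 log units; within the scatter). Compound 4 is therefore expected to give about 70000 nM in this assay, with a likely range from 20000 nM to 200000 nM.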

Compound 4, half-maximal inhibitory concentration: 12300 nM
For compound 4 the middle estimate is 5.7-fold (0.76 log units) above the measured one, outside the stated range (below it).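

Every earlier replacement of the 4-(trifluoromethyl)phenyl group on the carbon with a double bond to nitrogen had weakened the compound, but 3-nitrophenyl moves the result the other way in this assay with a 3.3-fold lower number from compound 1 to compound 4 (0.52 log units; beyond the scatter) as the step. This shows that a change at this position can strengthen the compound as well as weaken it, and compound 4 is the strongest of the four compounds shown. It also stands well clear of the other two replacements, with an at least 8.1-fold lower number from compound 3 to compound 4 (0.91 log units; beyond the scatter) and an at least 8.1-fold lower number from compound 2 to compound 4 (0.91 log units; beyond the scatter) as the steps, and the full size of each cannot be read for this reason: the limit of > 100000 nM in this assay, at which 2 of the 4 values shown sit.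

The compounds shown cannot separate the effect of the nitro group from that of its placement on the phenyl ring, since 4-nitrophenyl and plain phenyl are absent from this set. From the compounds shown here alone, it also remains open whether a phenyl ring carrying an amine or a carboxylic acid in place of the nitro group would keep this gain.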